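Cyanoaziridine ureas: trimming the nitrogen substituent to hydrogen

The source may report more compounds than this note shows. Statements on the series, on what has been measured and on what is new or still open speak of the compounds shown alone.

Compound 2 `CC(C)(C)NC(=O)N1CC1C#N` gives only a limit in a functional assay on MCF7 cells (Homo sapiens) for inhibition (a higher number here means a weaker inhibitor, a lower number a stronger inhibitor), > 300000 nM. Compound 1 `CCCCNC(=O)N1CC1C#N` likewise gives only a limit in this assay, > 12000 nM. The step that the two limits leave unreadable from compound 1 to compound 2 is therefore unreadable. Compound 3 `N#CC1CN1C(N)=O` differs from compound 2 as hydrogen in place of tert-butyl on an amide-type nitrogen. Among the measured compounds shown here, no measured step reads on this change; the two limits the limit of > 12000 nM in this assay, at which 1 of the 2 values shown sits, and the limit of > 300000 nM in this assay, at which 1 of the 2 values shown sits, show only that neither substituent on the amide-type nitrogen gave measurable inhibition, so another limit in this assay is the likeliest outcome. Compound 3 is expected at 250000 nM, range 30000 nM to 1000000 nM. The step of an at least 1.2-fold lower number from compound 2 to compound 3 (0.07 log units; that floor lies within the scatter) that this estimate means is expected to lie within the scatter.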

Compound 3, half-maximal inhibitory concentration: > 54000 nM
Compound 3: a limit, no number (the forecaster's own chance of this, stated with the estimate: 85%); the middle value does not contradict the limit.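

Among the compounds shown here, compound 1, compound 2 and compound 3 each give only a limit in this assay, so no step among them can be read. The compounds shown leave open whether any substituent on the amide-type nitrogen gives measurable inhibition.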